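The source may report more compounds than this note shows. Statements on the series, on what has been measured and on what is new or still open speak of the compounds shown alone.

Of the compounds shown here, three sharing one core have been tested in a functional assay on L02 cells (Homo sapiens) for inhibition, read by Griess assay, with stated times of 1 h and 24 h; a lower number here means a stronger inhibitor, a higher number a weaker inhibitor. Compound 1 `COc1ccc(Nc2nc(/C=C/c3ccccc3)nc3ccsc23)cc1` gives > 1000000 nM, which is a limit of the assay rather than a number. Compound 2 `CC(C)c1ccc(Nc2nc(/C=C/c3ccco3)nc3ccsc23)cc1` gives > 1000000 nM, again a limit. Compound 3 `COc1cc(/C=C/c2nc(Nc3ccc(C(C)C)cc3)c3sccc3n2)cc(OC)c1OC` is the only one of the three with a number, and in this assay compound 3 gives 370000 nM. Two of the three values shown sit at the limit of > 1000000 nM in this assay, at which 2 of the 3 values shown sit.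

Compound 4 `COc1cc(/C=C/c2nc(NCc3ccncc3)c3sccc3n2)cc(OC)c1OC` has not yet been measured. It differs from compound 3 in one place: (pyridin-4-yl)methyl in place of 4-isopropylphenyl on a nitrogen on an aromatic ring. Within the data shown here, no pair of measured compounds differs in just one place, so no step of this kind has been seen here, and nothing among the three measured compounds points to a large move in either direction. The step from compound 3 to compound 4 in this assay is expected to be a 1.4-fold higher number from compound 3 to compound 4 (0.13 log units; within the scatter), a small weakening within the usual scatter. Compound 4 is therefore estimated at 500000 nM, between 100000 nM and 2000000 nM, with a real chance that only a limit is reported.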

Compound 4, half-maximal inhibitory concentration: 374000 nM
Compound 4: the middle estimate sits 1.3-fold (0.13 log units) above what was measured; measured number inside the range.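

Among these compounds, putting (pyridin-4-yl)methyl in place of 4-isopropylphenyl on a nitrogen on an aromatic ring is the only single change that can be read in this assay, and it gives a 1.0-fold higher number from compound 3 to compound 4 (0.00 log units; within the scatter). Two quite different groups at this place, one with a ring of carbon only and one with a hetero atom in its ring, thus give values that cannot be told apart. The other values in this small set are limits, not numbers: the limit of > 1000000 nM in this assay, at which 2 of the 4 values shown sit.

From the compounds shown here alone, whether another group on this nitrogen, such as a morpholine, a carboxylic acid or a longer alkyl chain, would give a clearly different number stays open. Also open, going by these compounds, is whether the same swap would leave the result as flat in compound 1 or compound 2.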